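This account rests on a few compounds, and the source may have more. Where it says the series, first, only, none or still open, it means among the compounds named here.

In a functional assay on A549 cells (Homo sapiens) for antiproliferative activity, read by sulforhodamine B assay, with a stated time of 3 days (a lower number here means a stronger inhibitor of growth, a higher number a weaker inhibitor of growth), compound 1 `O=C(Nc1ccccn1)c1cccc(Nc2ncc(F)c(Nc3ccc(F)cc3)n2)c1` gives 15300 nM. Lacking the amide of compound 1, compound 2 `COc1ccc(N2CCN(C)CC2)cc1Nc1ncc(F)c(Nc2ccc(F)cc2)n1` gives 1130 nM, the lower of these two numbers. Compound 3 `O=C(Nc1nccs1)c1cccc(Nc2ncc(F)c(Nc3ccc(F)cc3)n2)c1` gives > 10000 nM, and this is a limit of the assay, not a number.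

Compound 4 `O=C(Nc1ccc(C(F)(F)F)cc1)c1cccc(Nc2ncc(F)c(Nc3ccc(F)cc3)n2)c1` differs from compound 3 on the amide: 4-(trifluoromethyl)phenyl in place of 1,3-thiazol-2-yl on an amide-type nitrogen. This puts 4-(trifluoromethyl)phenyl in place of 1,3-thiazol-2-yl on an amide-type nitrogen.

Within the data shown here, the only measured change at this place is a step that the limit leaves unreadable from compound 1 to compound 3, so no size can be carried over from it. That leaves compound 1 as the closest numerical guide, and with 15300 nM it points to weak growth inhibition for compound 4 as well. The expected change is a number no higher from compound 3 to compound 4 (the limit leaves the size open), with no direction that can be firmly predicted. For compound 4 the estimated value in this assay is 10000 nM, with an expected range of 3000 nM to 30000 nM.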

Compound 4, concentration for 50% growth inhibition: > 10000 nM
Compound 4: no number, only a limit; the forecaster's own chance of this, stated with the estimate: 40%; the middle value sits exactly at the limit.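

In this assay compound 4 gives > 10000 nM, which is a limit of the assay and not a number. No step from compound 3 or compound 1 to compound 4 can be read, because each involves a limit: the limit of > 10000 nM in this assay, at which 2 of the 4 values shown sit.

The compounds shown leave open how strongly compound 3 and compound 4 actually inhibit growth.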